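The source may hold more compounds than are shown below. What is called first, only, known or untested is meant among the compounds shown, and "the series" means these compounds.

Compound 1 `Cc1nn(-c2ccccc2Cl)c2c1C(c1ccc(Oc3ccccc3)cc1)SC(C)C(=O)N2`: 2700 nM
Compound 2 `Cc1ccccc1-n1nc(C)c2c1NC(=O)[C@H](C)S[C@@H]2c1ccc(-c2ccsc2)cc1`: 1400 nM

In an assay on isolated protein for agonist activity at Bile acid receptor (Homo sapiens), read by AlphaScreen, with a stated time of 30 min (on this read-out higher numbers stand for an effect only at larger amounts of compound and lower numbers for an effect already at smaller amounts), compound 2 gives 1400 nM and compound 1 gives 2700 nM; the two lie within the usual scatter of each other, so neither stands apart from the other. Compound 3 `Cc1ccccc1-n1nc(C)c2c1NC(=O)[C@H](C)S[C@@H]2c1ccc(-c2ccco2)cc1` is a single change away from compound 2: furan-2-yl in place of thiophen-3-yl on an aromatic carbon. For the measured compounds named here, no measured pair shows such a swap, so nothing here tells its size; a change of this kind is expected to stay within the scatter, with no clear direction. Compound 3 is therefore estimated at 2000 nM, between 700 nM and 6000 nM. That estimate corresponds to an expected step of a 1.4-fold higher number from compound 2 to compound 3 (0.15 log units; within the scatter).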

Compound 3, half-maximal effective concentration: 3600 nM
The estimate for compound 3 lay 1.8-fold (0.26 log units) below the measured number; the measured number falls inside the stated range.
By their numbers in this assay, from the lowest: compounds 2, 1 and 3 (each within the scatter of the next, the first and the last beyond it).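

For the compounds shown here, this is the first measured sign that the ring on this aromatic carbon, para to a large group, affects the result: in this assay furan-2-yl in place of thiophen-3-yl gives a 2.6-fold higher number from compound 2 to compound 3 (0.41 log units; beyond the scatter) even though both groups have the same heavy-atom and hydrogen-bond acceptor counts. The swap alters both the hetero atom and the ring's point of attachment, so the step cannot be assigned to either alone. Nothing available explains the step. Thiophen-2-yl and furan-3-yl could separate these two changes. As far as these compounds go, how a carboxylic acid or an amine would fare at this position remains open.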